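Fluoro for methyl on a phenol that shows no inhibition

The source may hold more compounds than are shown below. What is called first, only, known or untested is meant among the compounds shown, and "the series" means these compounds.

Compound 1, `COc1ccc(O)c(/C=N/c2ccc(OCc3ccccc3)cc2)c1`, gives in a functional assay, with a stated time of 30 min (on this read-out higher numbers stand for weaker inhibition and lower numbers for stronger inhibition), only a limit, > 200000 nM.
Compound 2, `Cc1ccc(O)c(/C=N/c2ccc(OCc3ccccc3)cc2)c1`, gives in this assay only a limit, > 200000 nM.

Compound 2 therefore stands at the edge of what this assay can report: its reading is a limit, not a number. Compound 3, `Oc1ccc(F)cc1/C=N/c1ccc(OCc2ccccc2)cc1`, has not yet been measured. It differs from compound 2 by fluoro in place of methyl on an aromatic carbon, para to a hydroxy group. Going by the values given here, the only measured step, a step that the two limits leave unreadable from compound 1 to compound 2, cannot be sized, because both of its ends sit at the limit of > 200000 nM in this assay, at which 2 of the 2 values shown sit. Among the compounds with values here, no step on record therefore gives a direction or a size for the change from compound 2 to compound 3, and nothing here points to inhibition appearing. The expectation for compound 3 is that this assay again reports a limit rather than a number, so the estimated step that the limit leaves unreadable from compound 2 to compound 3 is none beyond the scatter. Compound 3 is accordingly expected at 300000 nM, within 100000 nM to 1000000 nM.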

Compound 3, half-maximal inhibitory concentration: > 200000 nM
Compound 3: no number, only a limit; the forecaster's own chance of this, stated with the estimate: 80%; the middle value lies beyond the limit too.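

No step can be read among compound 1, compound 2 and compound 3, because each gives only a limit and not a number: the limit of > 200000 nM in this assay, at which 3 of the 3 values shown sit.

Going by these compounds, how far these three compounds differ from one another stays open, as does whether any group at this place would give a measurable value in this assay.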